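Nitro for Bromo on the Phenyl Ring of Compound 2

The source may hold more compounds than are shown below. What is called first, only, known or untested is meant among the compounds shown, and "the series" means these compounds.

Of the compounds shown here, two have been tested in a functional assay on the whole organism (strain Swiss albino) for inhibition, with Mus musculus as the target, with a stated time of 0.5 h; a lower number here means that less compound is needed, a higher number that more compound is needed for the effect. Compound 1 `COc1ccccc1-n1c(Nc2nc(-c3ccc([N+](=O)[O-])cc3)cs2)n[nH]c1=S` carries a nitro group on its phenyl ring and a methoxy group on the other aromatic ring; in this assay compound 1 gives 100 mg/kg. Compound 2 `Cc1ccccc1-n1c(Nc2nc(-c3ccc(Br)cc3)cs2)n[nH]c1=S` carries a bromo group on its phenyl ring and a methyl group on the other aromatic ring; in this assay compound 2 gives 30 mg/kg, the lowest of the two numbers, and the gap to compound 1 lies beyond the usual scatter. Within the data shown here, the two differ in two places, so no single step joins them.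

Compound 3 `Cc1ccccc1-n1c(Nc2nc(-c3ccc([N+](=O)[O-])cc3)cs2)n[nH]c1=S` keeps the methyl group of compound 2 and changes only the phenyl ring: nitro in place of bromo on an aromatic carbon. Since compound 1, the other nitro-bearing compound, gives 100 mg/kg, a step toward a higher number is expected, but of modest size. The two measured compounds differ in a second place as well, so the measured gap cannot be laid on the phenyl-ring change alone. The expected step from compound 2 to compound 3 is a 1.7-fold higher number from compound 2 to compound 3 (0.22 log units; within the scatter). Compound 3 is therefore estimated at 50 mg/kg, with a range from 20 mg/kg to 150 mg/kg.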

Compound 3, minimum effective dose: 100 mg/kg
Estimate against measurement, compound 3: 2.0-fold (0.30 log units) below, within the range that was stated.
By their numbers in this assay, from the lowest: compound 2; then compounds 1 and 3 (each within the scatter of the next).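

With the methyl group held in place, the 4-bromophenyl to 4-nitrophenyl exchange can now be read on its own in this assay (a 3.3-fold higher number from compound 2 to compound 3 (0.52 log units; beyond the scatter)), and this step at the phenyl ring is as large as the whole gap between the two earlier compounds. The second difference between those compounds does not show beyond the scatter: methyl in place of methoxy on an aromatic carbon gives no change at the digits printed from compound 1 to compound 3 (within the scatter), so this series offers no sign so far that the choice between these two groups matters at the other aromatic ring. No measurement at hand explains either of these results.

On these data alone, only bromo and nitro have been seen at this phenyl position, so it remains open where a smaller halogen such as fluoro, an amine or a carboxylic acid would fall in this whole-animal read-out. As far as these compounds go, it is also open whether the step seen with the methyl group would recur with the methoxy group, as bromo appears here only in the methyl-bearing compound 2.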